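A few compounds are considered here, and "the series" means these few. Any claim that something is new, unique, unknown or untested is made for them only; others in the source may bear on it.

Compound 1 `CCC(C)C1NC(=O)N(C2CCCC2)C1=O` is a small cyclic urea carrying a sec-butyl side chain. In a functional assay on HEL cells (Homo sapiens) for cytotoxicity (on this read-out lower numbers stand for higher toxicity in this test and higher numbers for lower toxicity in this test), compound 1 gives > 50 ug/mL, which is a limit of the assay rather than a measured number. The reading sits at the limit of > 50 ug/mL in this assay, at which 1 of the 2 values shown sits. Compound 2 `CCC(C)C(NC(=O)n1nnc2ccccc21)C(=O)NC(c1ccccc1)c1ccccc1`, built on a different skeleton, gives 40 ug/mL in this assay. Compound 3 `CC(C)C1NC(=O)N(C2CCCC2)C1=O` shares the core of compound 1 and differs from it in one place only, hydrogen in place of methyl on a saturated chain carbon, two bonds along the chain from a saturated ring carbon, so that sec-butyl reads as isopropyl. Among the measured compounds shown here, no step between measured compounds is available here, so the size of this move cannot be read from the data. Trimming a single methyl is expected to leave this assay's result within the usual scatter, with no clear direction, so the step that the limit leaves unreadable from compound 1 to compound 3 is expected to be small. Compound 3 is therefore estimated at 60 ug/mL in this assay, with a range from 35 ug/mL to 120 ug/mL, and most likely again only a limit.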

Compound 3, half-maximal cytotoxic concentration: > 50 ug/mL
Compound 3 was reported as a limit; the forecaster's own chance of this, stated with the estimate: 75%; the middle value lies beyond the limit too.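

No step can be read between compound 1 and compound 3, as both results are limits of the assay and not numbers: the limit of > 50 ug/mL in this assay, at which 2 of the 3 values shown sit. Going by these compounds, whether swapping sec-butyl for isopropyl changes the result in this assay at all, and how far beyond the limit either compound lies, stays open.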